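A few compounds are considered here, and "the series" means these few. Any claim that something is new, unique, unknown or untested is made for them only; others in the source may bear on it.

For the measured compounds named here, compound 2 `CC1(C)Oc2ccc(S(=O)(=O)N3CCCCC3)cc2[C@@H](/N=C(\NC#N)Nc2ccc(Cl)cc2)[C@@H]1O` stands as the stronger of the two compounds measured so far: in a functional assay (aorta) with Rattus norvegicus as the target (a lower number here means a stronger inhibitor, a higher number a weaker inhibitor), compound 2 gives 1900 nM, whereas compound 1 `C=C(c1ccccc1)c1ccc2c(c1)[C@@H](/N=C(\NC#N)Nc1ccc(Cl)cc1)[C@H](O)C(C)(C)O2` gives 10700 nM. Going by the values given here, the only measured step, a 5.6-fold lower number from compound 1 to compound 2 (0.75 log units; beyond the scatter), arises from exchanging the 1-phenylethenyl group on the aromatic carbon for a (piperidin-1-yl)sulfonyl group, and it places compound 2 at the lowest number of the pair by a margin beyond the scatter.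

Compound 3 `CC(C)CN(CC(C)C)S(=O)(=O)c1ccc2c(c1)[C@@H](/N=C(\NC#N)Nc1ccc(Cl)cc1)[C@H](O)C(C)(C)O2` keeps the sulfonyl group on that aromatic carbon and alters only what sits on the sulfur: diisobutylamino in place of piperidin-1-yl on a sulfonyl sulfur. Among the compounds with values here, no measured step touches the amine part of the sulfonamide, so the step from compound 1 to compound 2 speaks only to the presence of the sulfonyl group, not to the choice between a ring and two open chains on its nitrogen. With nothing to show that this change matters either way, the step in this assay is expected to stay within the scatter or close to it, as a 1.3-fold higher number from compound 2 to compound 3 (0.12 log units; within the scatter). Compound 3 is therefore estimated at 2500 nM, with a range from 700 nM to 9000 nM.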

Compound 3, half-maximal inhibitory concentration: 9400 nM
The estimate for compound 3 lay 3.8-fold (0.58 log units) below the measured number; measured number above the stated range.
By their numbers in this assay, from the lowest: compound 2; then compounds 3 and 1 (each within the scatter of the next).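

In this assay, the amine part on the sulfonyl sulfur turns out to matter: diisobutylamino in place of piperidin-1-yl gives a 4.9-fold higher number from compound 2 to compound 3 (0.69 log units; beyond the scatter), so the sulfonyl group alone does not set the number. With diisobutylsulfamoyl in place of 1-phenylethenyl on the aromatic carbon, the step reads a 1.1-fold lower number from compound 1 to compound 3 (0.06 log units; within the scatter), which puts compound 1 and compound 3 level, and of the three compounds only compound 2, with its (piperidin-1-yl)sulfonyl group, stands apart from the others. Nothing at hand bears on the reason for these steps.

The compounds shown leave open whether the ring itself or the size of the amine part goes with the lower number, a question that a small open amine such as dimethylamino, or a pyrrolidine or morpholine ring on the sulfonyl sulfur, would help to separate. Going by these compounds, it also remains open how a sulfonyl group carrying a primary amine, or a different group such as an amide or a carboxylic acid on the aromatic carbon, would compare with compound 2.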